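Bromo for Chloro on the Pendant Ring: Clearance Expectation

The source may hold more compounds than are shown below. What is called first, only, known or untested is meant among the compounds shown, and "the series" means these compounds.

Among the measured compounds shown here, only two numbers exist so far. Compound 2 `Clc1ccc(Cn2nnc3c(Br)cccc32)cc1` gives 2.2 mL/min/g in an ADME assay on microsomes from liver (Rattus norvegicus, strain Wistar) for metabolic stability, tested at 2.5 uM (a lower number here means slower removal, a higher number faster removal of the compound), and compound 1 `Brc1cccc2c1nnn2Cc1ccccc1` gives 2 mL/min/g in this assay, so the two stand within the scatter of each other and neither can be called slower or faster. For the measured compounds named here, the single measured step, a 1.1-fold higher number from compound 1 to compound 2 (0.04 log units; within the scatter), introduced a halogen on the same six-membered ring and left the number essentially where it was. Compound 3 `Brc1ccc(Cn2nnc3c(Br)cccc32)cc1` differs from compound 2 by bromo in place of chloro on an aromatic carbon. Going by the values given here, no measured step exchanges one halogen for another, so the only guide is the step from compound 1 to compound 2, which stayed within the scatter. Compound 3 is therefore expected to remain close to compound 2, with the step of a 1.1-fold higher number from compound 2 to compound 3 (0.04 log units; within the scatter) expected to lie within the scatter. Compound 3 is estimated at 2.4 mL/min/g in this assay, with a range of 1.3 mL/min/g to 4.5 mL/min/g.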

Compound 3, intrinsic clearance in a liver preparation (reported as CLH), per the amount of preparation that the assay uses: 2.2 mL/min/g
Compound 3: middle estimate off by 1.1-fold (0.04 log units), on the high side; the range from low to high includes it.
By their numbers in this assay, from the lowest: compounds 1, 2 and 3 (each within the scatter of the next).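

Among the compounds shown here, the exchange of chloro for bromo on an aromatic carbon para to a large group is the first swap of one halogen for another at this position, and in this assay it gives no change at the digits printed from compound 2 to compound 3 (within the scatter) for this pair. Bromo in place of hydrogen at the same place gives a 1.1-fold higher number from compound 1 to compound 3 (0.04 log units; within the scatter) as well, so the hydrogen, chloro and bromo forms, compound 1, compound 2 and compound 3, all stand within the scatter of one another. No outside evidence bears on why these numbers stay together.

Going by these compounds, whether an amine or a carboxylic acid at this place would carry the number in this assay beyond the scatter remains open. Also open, on these data alone, is what a methoxy or a nitrile in place of the bromo on the shared core would do.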